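Cyclopropyl ketone to propyl ketone on a shared core

The source may hold more compounds than are shown below. What is called first, only, known or untested is meant among the compounds shown, and "the series" means these compounds.

Measured so far:
- compound 1 `CC1=C(C(=O)OCc2ccccc2)C(c2cccs2)NC(=O)N1`: in an assay on membranes from HEK293 cells for displacement of a labelled ligand from adenosine receptor A2b (Homo sapiens), read by scintillation counting, with a stated time of 30 min (a higher number here means a weaker inhibitor, a lower number a stronger inhibitor), compound 1 gives 1920 nM
- compound 2 `CC1=C(C(=O)C2CC2)C(c2ccco2)NC(=O)N1`: in this assay compound 2 gives 1060 nM

Compound 2 has the lower of the two numbers, yet its distance to compound 1 is within the usual scatter of this assay, so the two cannot be told apart. Among the compounds with values here, no pair of measured compounds differs in only one place, so no single step has been measured here.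

Compound 3 `CCCC(=O)C1=C(C)NC(=O)NC1c1ccco1` is not yet measured. It differs from compound 2 in one place: propyl in place of cyclopropyl on a carbonyl carbon. The ketone stays; only the three-carbon group attached to it changes from a ring to an open chain. Without a measured step of this kind, the expectation is for no change beyond the scatter, perhaps a slight weakening. The step of a 1.3-fold higher number from compound 2 to compound 3 (0.12 log units; within the scatter) is what this estimate implies. Compound 3 is expected to give 1400 nM in this assay, within 500 nM to 4000 nM.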

Compound 3, inhibition constant: 807 nM
Compound 3: middle estimate off by 1.7-fold (0.24 log units), on the high side; measured number inside the range.
By their numbers in this assay, from the lowest: compounds 3, 2 and 1 (each within the scatter of the next, the first and the last beyond it).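

In this assay, within the data shown here, this is the first single-place change that can be read at this position: a 1.3-fold lower number from compound 2 to compound 3 (0.12 log units; within the scatter) when propyl takes the place of cyclopropyl on the carbonyl carbon. The ring is therefore not needed to keep binding at this level, as an open chain of the same 3 carbons cannot be told apart from it in this measurement. No separate measurement bears on why the two groups read alike.

On these data alone, it remains open whether this carbonyl carbon accepts a larger change, such as a longer chain like pentyl, a phenyl ring or an amine, which would turn the ketone into an amide. As far as these compounds go, this conclusion also rests on a single pair of compounds, so whether it carries over to other groups on the shared core is unknown.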